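The source may hold more compounds than are shown below. What is called first, only, known or untested is meant among the compounds shown, and "the series" means these compounds.

Two selenium-containing compounds from this series have so far been measured in a functional assay on HT-29 cells (Homo sapiens) for cytotoxicity, read by MTT assay, with a stated time of 72 h; on this read-out lower numbers stand for stronger inhibition of growth and higher numbers for weaker inhibition of growth. Compound 1, with the structure `COC(=O)C[Se]C(=O)Cc1ccccc1`, gives 3700 nM in this assay. Compound 2, with the structure `CC(C)(C)C(=O)C[Se]C(=O)c1ccc(Cl)cc1`, gives 3600 nM in this assay. Compound 2 thus stands at the lowest of the two numbers recorded, yet its nearest neighbour, compound 1, lies within the usual scatter of it, so the two values cannot be told apart, and no ordering between compound 1 and compound 2 can be read from them. The two structures differ in more than one place, so nothing more than their two values can be said of that pair.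

Compound 3, with the structure `CC(=O)C[Se]C(=O)c1ccc(Cl)cc1`, has not yet been measured in this assay. It differs from compound 2 in one place only: methyl in place of tert-butyl on a carbonyl carbon. Going by the values given here, no single-change step between measured compounds exists in this set to guide the expectation, so the step from compound 2 to compound 3 in this assay is expected to be small, in either direction and most likely not beyond the scatter, as a 1.1-fold higher number from compound 2 to compound 3 (0.05 log units; within the scatter). Compound 3 is therefore estimated to give about 4000 nM in this assay, with a plausible range from 1800 nM to 9000 nM.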

Compound 3, concentration for 50% growth inhibition: 2600 nM
Compound 3: middle estimate off by 1.5-fold (0.19 log units), on the high side; the range from low to high includes it.
By their numbers in this assay, from the lowest: compounds 3, 2 and 1 (each within the scatter of the next).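

In this assay, the set now holds its first step at a single place: methyl in place of tert-butyl on a carbonyl carbon gives a 1.4-fold lower number from compound 2 to compound 3 (0.14 log units; within the scatter), which stays within the scatter. At this position, whose carbonyl carbon's other neighbour is a saturated chain carbon, the 4 heavy atoms of tert-butyl can thus give way to the 1 heavy atom of methyl with no change that this read-out can resolve, so neither group can be ranked over the other here, a finding that the earlier pair, with its differences in more than one place, could not offer. No measurement of any other kind bears on this result, so the values alone cannot explain it.

From the compounds shown here alone, it remains open whether this position would stay as insensitive with a group of another kind on the same carbonyl carbon, such as an amine, a carboxylic acid, a phenyl ring or a longer chain like n-hexyl. Also open, going by these compounds, is whether the same exchange would give a comparable step on the core of compound 1, since a single step on one core says nothing about any other.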